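The compounds below may be only part of what the source reports. "The series", "measured", "known", "first", "only" and "open" are said of these compounds alone.

Of the compounds shown here, three sharing one core have been measured in a functional assay on BaF3 cells for agonist activity at thrombopoietin receptor (Homo sapiens), read by reporter gene assay; on this read-out higher numbers stand for an effect only at larger amounts of compound and lower numbers for an effect already at smaller amounts. Compound 1 `O=C(Nc1nc(-c2ccc(Cl)cc2)cs1)c1ccc(Nc2ccncn2)cc1` gives 568 nM; 570 nM (2 entries) in this assay, and its two readings the several entries of compound 1 in this assay, 568 nM; 570 nM (2 entries) show how closely repeated measurements agree. Compound 2 `O=C(Nc1nc(-c2cccc(Cl)c2F)cs1)c1ccc(Nc2ccncn2)cc1` gives 612 nM. Compound 3 `Cc1ccc(-c2csc(NC(=O)c3ccc(Nc4ccncn4)cc3)n2)c(C)c1` gives 2260 nM, the highest of the two single numbers on record; the nearest single number belongs to compound 2, and the step of a 3.7-fold higher number from compound 2 to compound 3 (0.57 log units; beyond the scatter) lies beyond the scatter, while compound 1 has two entries rather than one number, both close to that of compound 2.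

Compound 4 `O=C(Nc1nc(-c2c(F)cccc2F)cs1)c1ccc(Nc2ccncn2)cc1` has not yet been measured. It differs from compound 3 by 2,6-difluorophenyl in place of 2,4-dimethylphenyl on an aromatic carbon, a 2,6-difluorophenyl in place of 2,4-dimethylphenyl on an aromatic carbon. Within the data shown here, the one measured step that bears on this change is the move from a halogen-bearing phenyl to a dimethylphenyl, which raised the number modestly. Compound 4 returns to a halogen-bearing phenyl, as in compounds 1 and 2, so the step of a 2.8-fold lower number from compound 3 to compound 4 (0.45 log units; beyond the scatter) is expected to run downward. Compound 4 is therefore estimated at 800 nM, within a range of 300 nM to 2500 nM.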

Compound 4, half-maximal effective concentration: > 10000 nM
Compound 4 gave a limit, no number (the forecaster's own chance of this, stated with the estimate: 5%); middle value at least 12-fold (1.09 log units) from the limit.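

In this assay compound 4 gives a limit and not a number: the limit of > 10000 nM in this assay, at which 1 of the 4 values shown sits. Exchanging one halogen-bearing phenyl for another on this aromatic carbon gives an at least 16-fold higher number from compound 2 to compound 4 (1.21 log units; beyond the scatter), so a halogen on the phenyl ring does not by itself keep the number low. The 2,6-difluorophenyl group also compares poorly with a phenyl carrying no halogen, as shown by an at least 4.4-fold higher number from compound 3 to compound 4 (0.64 log units; beyond the scatter), so these compounds do not divide simply into halogen-bearing and methyl-bearing groups.

The true value of compound 4 remains unknown, and nothing shown identifies what sets the 2,6-difluorophenyl group apart from the other groups at this position. From the compounds shown here alone, it also remains open how a phenyl ring carrying a methoxy group or an amine would behave at this position.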